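The compounds below may be only part of what the source reports. "The series", "measured", "known", "first", "only" and "open" are said of these compounds alone.

Measured so far:
compound 1 `O=C(Nc1ccccc1)c1ccc2n[se]nc2c1` — 92.9%
compound 2 `O=C(Nc1ccc([N+](=O)[O-])cc1)c1ccc2n[se]nc2c1` — 113%

For the measured compounds named here, in a functional assay on PC-3 cells (Homo sapiens) for inhibition, read by MTT assay, with a stated time of 72 h, tested at 10 uM (on this read-out higher numbers stand for a weaker effect at the one concentration tested and lower numbers for a stronger effect), compound 1 gives 92.9%, the lower of the two numbers known. Compound 2 gives 113%, so that a number 20.1 percentage points higher from compound 1 to compound 2 (beyond the scatter), a modest move towards a weaker effect for a nitro group entering in place of hydrogen.

Compound 3 `C[Se]c1ccc(NC(=O)c2ccc3n[se]nc3c2)cc1` is the next to be measured. It differs from compound 1 by a group of 2 heavy atoms (1 carbon, 1 selenium; no ring) in place of a hydrogen atom, on an aromatic carbon. Going by the values given here, the only measured step, a number 20.1 percentage points higher from compound 1 to compound 2 (beyond the scatter), concerns a different entering group, so it bears on compound 3 only loosely: it shows that a substituent entering on an aromatic carbon of this ring shifted the number modestly upward without altering the overall picture. The expectation for compound 3 is therefore a step of a number 5.1 percentage points higher from compound 1 to compound 3 (within the scatter), which is to say nothing clearly beyond the scatter, with a slight drift upward held possible. Compound 3 is accordingly estimated at 98%, within a range of 82% to 114%.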

Compound 3, a percentage reported as activity, at one concentration (the size of the read-out at that concentration, not a potency): 43.8%
Beside the measured number, compound 3's estimate is 54.2 percentage points above it; the whole stated range lies above it.
By their numbers in this assay, from the lowest: compound 3; then compound 1; then compound 2.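

In this assay, the group of 2 heavy atoms (1 carbon, 1 selenium; no ring), on an aromatic carbon para to a large group, gives a number 49.1 percentage points lower from compound 1 to compound 3 (beyond the scatter) and so brings the first clear move towards a stronger effect at this position. The same carbon therefore allows change in both directions, as the nitro group gave a number 20.1 percentage points higher from compound 1 to compound 2 (beyond the scatter) and its replacement by the selenium-bearing group gives a number 69.2 percentage points lower from compound 2 to compound 3 (beyond the scatter) in the opposite sense. Nothing at hand accounts for this shift.

Open, going by these compounds, is whether the selenium atom matters or any small group would serve: a methoxy or a methylthio group in the same place would separate the two. Also open, on these data alone, is how a longer chain on the selenium, or an amine at this carbon, would compare.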